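Adding a Methyl Beside the Ring Amine: Expected Potency

The compounds below may be only part of what the source reports. "The series", "measured", "known", "first", "only" and "open" are said of these compounds alone.

Measured compounds:
Compound 1, `CCN1CC[C@@]2(OC)OC(N)=C(C#N)[C@@H](c3ccccc3)[C@@H]2C1`, gives 23400 nM in a functional assay on trachea (Cavia porcellus); a lower number here means a stronger inhibitor, a higher number a weaker inhibitor.
Compound 2, `CCCN1CC[C@@]2(OC)OC(N)=C(C#N)[C@@H](c3ccccc3)[C@@H]2C1`, gives 20700 nM in this assay.
Compound 3, `COc1ccc([C@@H]2C(C#N)=C(N)O[C@]3(OC)CCN(C)C[C@@H]23)cc1`, gives 23100 nM in this assay.

From compound 1 to compound 2 the structural change is methyl in place of hydrogen on a saturated chain carbon, two bonds along the chain from an amine nitrogen in a ring, and the measured step is a 1.1-fold lower number from compound 1 to compound 2 (0.05 log units; within the scatter). Compound 4, `CCN1CC[C@@]2(OC)OC(N)=C(C#N)[C@@H](c3ccc(OC)cc3)[C@@H]2C1`, is not yet measured; it stands to compound 3 as methyl in place of hydrogen on a saturated chain carbon bound to an amine nitrogen in a ring. This is the same kind of change as the earlier one, but the place differs: here the methyl enters on a saturated chain carbon bound to an amine nitrogen in a ring, whereas earlier it entered on a saturated chain carbon two bonds along the chain from an amine nitrogen in a ring. The difference between the core of compound 1 and the core of compound 3 is not broken down here. Because the measured step of a 1.1-fold lower number from compound 1 to compound 2 (0.05 log units; within the scatter) lies within the scatter, the expected step is a 1.1-fold lower number from compound 3 to compound 4 (0.04 log units; within the scatter), a small one. Compound 4 is therefore estimated at 21000 nM, with a likely range from 10000 nM to 45000 nM.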

Compound 4, half-maximal inhibitory concentration: 25500 nM
For compound 4 the middle estimate is 1.2-fold (0.08 log units) below the measured one, within the range that was stated.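

In this assay, the methyl step on the second core is a 1.1-fold higher number from compound 3 to compound 4 (0.04 log units; within the scatter), and methoxy in place of hydrogen on an aromatic carbon gives a 1.1-fold higher number from compound 1 to compound 4 (0.04 log units; within the scatter). Set beside the earlier step, the new one agrees with it: the same change on two cores in this assay, a 1.1-fold lower number (0.05 log units; within the scatter) from compound 1 to compound 2 and a 1.1-fold higher number (0.04 log units; within the scatter) from compound 3 to compound 4, 1.2-fold (0.10 log units) apart, within the scatter of two such steps. This shows that the change stays within the scatter on both cores, but not that a step of real size would carry over, and the methyl enters at a different place on the chain in each case.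

The compounds shown leave open whether a longer chain such as butyl would move the number beyond the scatter. The same question stands for a carboxylic acid in place of the methoxy.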